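Ester to Acid: Stability in Rat Liver Fraction

The source may hold more compounds than are shown below. What is called first, only, known or untested is meant among the compounds shown, and "the series" means these compounds.

Measured in an ADME assay on S9 fraction from liver (Rattus norvegicus) for metabolic stability, read by LC-MS, using NADPH, with a stated time of 30 min; a lower number here means that less of the compound is left, a higher number that more of the compound is left:
Compound 1 `CCCCCCCCc1ccc(OCC(=O)Cn2nnc(-c3cccc(C(=O)OC)c3)n2)cc1` gives 19%.
Compound 2 `CCCCCCCCc1ccc(OCC(=O)Cn2nnc(-c3cccc(C(=O)O)c3)n2)cc1` gives < 5%; this value is a limit of the assay, not a number (the limit of < 5% in this assay, at which 1 of the 3 values shown sits).
Compound 3 `CCCCCCCCc1ccc(OC(C)C(=O)Cn2nnc(-c3ccc(C(=O)OC)cc3)n2)cc1` gives 62%.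

Compound 1 and compound 2 differ by hydrogen in place of methyl on an oxygen next to a carbonyl group, and this change produced a number at least 14 percentage points lower from compound 1 to compound 2 (beyond the scatter). Of the two numbers shown, compound 3 stands highest, with compound 1 as its nearest neighbour.

Compound 4 `CCCCCCCCc1ccc(OC(C)C(=O)Cn2nnc(-c3ccc(C(=O)O)cc3)n2)cc1` has not yet been measured. It differs from compound 3 by hydrogen in place of methyl on an oxygen next to a carbonyl group, the same change at the same place as that from compound 1 to compound 2. The cores of compound 1 and compound 3 differ, but that difference is not broken down here.

For compound 4 a downward step is expected, a number 37 percentage points lower from compound 3 to compound 4 (beyond the scatter), because a number at least 14 percentage points lower from compound 1 to compound 2 (beyond the scatter) shows the same change lowering the remaining fraction. Compound 4 is therefore estimated at 25%, expected to lie between 5% and 50%.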

Compound 4, percent of the compound remaining: 55%
Compound 4: the middle estimate sits 30 percentage points below what was measured; measured number above the stated range.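

On the core of compound 3, replacing methoxycarbonyl with carboxy gives a number 7 percentage points lower from compound 3 to compound 4 (within the scatter) in this assay, so no real effect of the change can be read on this core. Compound 2 gives < 5%, which is a limit of the assay and not a number. The two steps therefore do not show that the change carries over unchanged from one core to the other, nor that its effect depends on the core: the same change on two cores in this assay, a number at least 14 percentage points lower (beyond the scatter) from compound 1 to compound 2 and a number 7 percentage points lower (within the scatter) from compound 3 to compound 4; the limit leaves it open whether they differ

The compounds shown do not break down the difference between the two cores into single changes. They also leave open how a primary amide in place of the carboxy group would fare on either core.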